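The compounds below may be only part of what the source reports. "The series", "measured", "known", "first", "only" and "open" are said of these compounds alone.

Measured compounds in the series:

compound 1, `N#Cc1ccc(NC(=O)c2cc(Cl)ccc2O)c(Cl)c1`: in a physicochemical assay for solubility (a higher number here means a more soluble compound, a lower number a less soluble compound), compound 1 gives only a limit, < 1 ug/mL.
compound 2, `O=C(Nc1ccc(C(F)(F)F)cc1Cl)c1cc(Cl)ccc1O`: in this assay compound 2 gives only a limit, < 1 ug/mL.
compound 3, `O=C(Nc1ccc(C(F)(F)F)cc1Cl)c1ccc2ccccc2c1O`: in this assay compound 3 gives only a limit, < 1 ug/mL.

Compound 4, `N#Cc1ccc(NC(=O)c2ccc3ccccc3c2O)c(Cl)c1`, is not yet measured. It differs from compound 3 in one place: cyano in place of trifluoromethyl on an aromatic carbon. The same change is made from compound 2 to compound 1, both measured: cyano in place of trifluoromethyl on an aromatic carbon. The two place descriptions read the same word for word, so this is the same change made on a second core. Its measured step is a step that the two limits leave unreadable from compound 2 to compound 1; both ends of that pair sit at the limit, so nothing about the size or direction of the change can be read from it. How the core of compound 3 differs from the core of compound 2 is not broken down here. The one clear feature of the measured set is the limit of < 1 ug/mL in this assay, at which 3 of the 3 values shown sit.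

With nothing in the measured pair to suggest movement, the step from compound 3 to compound 4 is expected to be a step that the limit leaves unreadable from compound 3 to compound 4, resting on the unreadable a step that the two limits leave unreadable from compound 2 to compound 1 and on compound 3 sitting at the limit with < 1 ug/mL. Compound 4 is expected to report only a limit again, with an estimated value of 0.5 ug/mL and a range of 0.1 ug/mL to 2 ug/mL.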

Compound 4, solubility: 6 ug/mL
Compound 4: middle estimate off by 12-fold (1.08 log units), on the low side; measured number outside the range, above it.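

Carried onto the core of compound 3, cyano in place of trifluoromethyl on an aromatic carbon gives in this assay an at least 6.0-fold higher number from compound 3 to compound 4 (0.77 log units; beyond the scatter), a step beyond the scatter and the only readable instance of this change in the series. From the compounds shown here alone, the same change on the other core, from compound 2 to compound 1, cannot be read, since both ends sit at a limit, so the notes show neither that the step carries over between cores nor that it fails to, and its size and direction on that core stay unknown. Compound 3 itself gives only a limit, < 1 ug/mL, so the step is a lower bound and not a measured size, and its lower end rests on the floor of the assay: the limit of < 1 ug/mL in this assay, at which 3 of the 4 values shown sit.

Going by these compounds alone, compound 4 is the only compound here with a readable number, so any further change on this core can be judged against it, but nothing yet tells how an amine or a carboxylic acid on that aromatic carbon would read in this assay. Within the data shown here, also open is whether the reading for compound 4 depends on its core, as no pair of cores can yet be compared above the limit.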